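The compounds below may be only part of what the source reports. "The series", "measured", "known", "first", "only" and "open" are said of these compounds alone.

Measured so far:
- compound 1 `CC(C)NC(=O)NS(=O)(=O)c1cc(C#N)ccc1Oc1ccc(F)cc1`: 9620 nM
- compound 2 `CC(C)(C)NC(=O)NS(=O)(=O)c1cc(C#N)ccc1Oc1ccc(F)cc1`: 4350 nM

In a functional assay on HEK293 cells for antagonist activity at thromboxane A2 receptor (Homo sapiens), read by fluorescence and calcium flux (a lower number here means a stronger inhibitor, a higher number a weaker inhibitor), compound 1 gives the highest of the two numbers; the nearest is compound 2, reached by a 2.2-fold lower number from compound 1 to compound 2 (0.34 log units; beyond the scatter). Compound 3 `Cc1ccccc1Nc1ccc(C#N)cc1S(=O)(=O)NC(=O)NC(C)C` differs from compound 1 by (2-methylphenyl)amino in place of 4-fluorophenoxy on an aromatic carbon. For the measured compounds named here, no measured step touches this place; the only known step concerns the chain on the amide-type nitrogen, not the aromatic position, so it gives no direct guide. The expectation for compound 3 is therefore a number near that of compound 1, with a wide range, and compound 3 is estimated at 6000 nM, between 1500 nM and 25000 nM, which means an expected step of a 1.6-fold lower number from compound 1 to compound 3 (0.21 log units; within the scatter).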

Compound 3, half-maximal inhibitory concentration: 7240 nM
For compound 3 the middle estimate is 1.2-fold (0.08 log units) below the measured one; low and high end bracket the measured number.
By their numbers in this assay, from the lowest: compounds 2, 3 and 1 (each within the scatter of the next, the first and the last beyond it).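

In this assay swapping 4-fluorophenoxy for (2-methylphenyl)amino on this aromatic carbon gives a 1.3-fold lower number from compound 1 to compound 3 (0.12 log units; within the scatter) and so leaves the number within the scatter. This position therefore accepts a different linking atom, a moved ring substituent and one added hydrogen-bond donor together, with no readable shift. No evidence is available on the reason for this. Still open, on these data alone, is what each part of the swap does alone, since they changed together. A 4-fluorophenylamino or plain phenylamino group at this position would begin to separate them.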